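A few compounds are considered here, and "the series" means these few. Any claim that something is new, unique, unknown or untested is made for them only; others in the source may bear on it.

Measured so far in a functional assay on A-375 cells (Homo sapiens) for cytotoxicity, read by MTT assay; a lower number here means a stronger inhibitor, a higher number a weaker inhibitor:
- compound 1, `O=C(NCCCNc1nccc(-c2c(-c3cccc(F)c3)nc3sccn23)n1)c1ccc(Cl)cc1`: 13700 nM
- compound 2, `O=S(=O)(NCCNc1nccc(-c2c(-c3cccc(F)c3)nc3sccn23)n1)c1ccc(C(F)(F)F)cc1`: 7440 nM
- compound 3, `Cc1ccc(S(=O)(=O)NCCNc2nccc(-c3c(-c4cccc(F)c4)nc4sccn34)n2)cc1`: 15400 nM

All three share one core and differ only in the chain and the group hung from it. Compound 3 gives the highest of the three numbers in this assay, but one of its two gaps is a 1.1-fold higher number from compound 1 to compound 3 (0.05 log units; within the scatter), so those two cannot be told apart, while the other is a 2.1-fold higher number from compound 2 to compound 3 (0.32 log units; beyond the scatter), a modest but real difference.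

Compound 4, `O=S(=O)(NCCNc1nccc(-c2c(-c3cccc(F)c3)nc3sccn23)n1)c1ccccc1`, is the next step from compound 3: hydrogen in place of methyl on an aromatic carbon. For the measured compounds named here, only one measured step touches the same place on the ring, the one where trifluoromethyl gave way to methyl, a 2.1-fold higher number from compound 2 to compound 3 (0.32 log units; beyond the scatter). That step shrank the group and the number rose a little. Removing the methyl shrinks the group once more, and a single step in one direction is thin ground for a trend, so the expectation is a small rise in the number, or none beyond the scatter, rather than a large move.

On that basis compound 4 is expected to give about 18000 nM in this assay, within a range of 8000 nM to 40000 nM, which corresponds to an expected step of a 1.2-fold higher number from compound 3 to compound 4 (0.07 log units; within the scatter).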

Compound 4, half-maximal inhibitory concentration: 11000 nM
Compound 4: the middle estimate sits 1.6-fold (0.21 log units) above what was measured; measured number inside the range.
By their numbers in this assay, from the lowest: compounds 2, 4, 1 and 3 (each within the scatter of the next, the first and the last beyond it).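

In this assay, hydrogen in place of methyl on this aromatic carbon gives a step that cannot be told from the scatter (a 1.4-fold lower number from compound 3 to compound 4 (0.15 log units; within the scatter)), and hydrogen in place of trifluoromethyl behaves the same way (a 1.5-fold higher number from compound 2 to compound 4 (0.17 log units; within the scatter)). The earlier step from trifluoromethyl to methyl therefore does not extend into a trend with the size of the group, and compound 4 goes against any such trend, since the unsubstituted phenyl cannot be separated from either substituted ring. Swapping the whole chain end also leaves compound 4 within the scatter of the chlorophenyl carbonyl compound (a 1.2-fold lower number from compound 1 to compound 4 (0.10 log units; within the scatter)), and nothing available explains why these numbers stay so close.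

As far as these compounds go, the ring position has carried only methyl, trifluoromethyl or hydrogen, so it remains open whether an amine, a carboxylic acid or a methoxy group there would move the number beyond the scatter. From the compounds shown here alone, it is also open whether a longer chain would change the number for the phenylsulfonyl compounds, since in compound 1 the chain and the end group differ together.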